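The source may hold more compounds than are shown below. What is called first, only, known or untested is meant among the compounds shown, and "the series" means these compounds.

Measured compounds:

Compound 1, `CCC(CC)(c1nnc[nH]1)c1ccc(-c2ccc3cc(F)cc(F)c3c2)[nH]c1=O`, in a functional assay on CHO cells for antagonist activity at prostaglandin E2 receptor EP3 subtype (Homo sapiens), read by cAMP accumulation (on this read-out higher numbers stand for weaker inhibition and lower numbers for stronger inhibition), compound 1 gives 350 nM.
Compound 2, `CC(C)C(Cc1ncc[nH]1)c1ccc(-c2ccc3cccc(F)c3c2)[nH]c1=O`, in this assay compound 2 gives 76 nM.
Compound 3, `CCn1ncc2c(F)cc(-c3ccc(C(CC)(CC)c4nnc[nH]4)c(=O)[nH]3)cc21`, in this assay compound 3 gives 29 nM.

Of these three, compound 3 stands at the lowest number in this assay, and its gap to compound 2, the nearest of the others, lies beyond the scatter, as does its far larger gap to compound 1. Within the data shown here, no pair among them differs in one place only, so the three values are read as separate points rather than as steps.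

Compound 4, `CCn1ncc2c(F)cc(-c3ccc(C(CC)(CC)c4nnc(C)[nH]4)c(=O)[nH]3)cc21`, is the one not yet measured. It differs from compound 3 by a methyl in place of hydrogen on an aromatic carbon. Among the measured compounds shown here, no pair of measured compounds shows a change of this kind, so there is nothing in the data to set its size or direction. A single carbon added to a small ring far from the rest of the molecule is expected to move the number little, and the step from compound 3 to compound 4, a 1.2-fold higher number from compound 3 to compound 4 (0.08 log units; within the scatter), is estimated to fall within the scatter.

For compound 4 in this assay the expected value is 35 nM, with a range from 12 nM to 100 nM.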

Compound 4, half-maximal inhibitory concentration in the prostaglandin E2 receptor EP3 subtype assay: 90 nM
The estimate for compound 4 lay 2.6-fold (0.41 log units) below the measured number; the measured number falls inside the stated range.
By their numbers in the prostaglandin E2 receptor EP3 subtype assay, from the lowest: compound 3; then compounds 2 and 4 (each within the scatter of the next); then compound 1.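

Among these compounds, replacing hydrogen with methyl on the aromatic carbon between two ring nitrogen atoms gives the first comparison here that differs in one place, and in the prostaglandin E2 receptor EP3 subtype assay compound 3 gives 29 nM and compound 4 gives 90 nM, which reads as a 3.1-fold higher number from compound 3 to compound 4 (0.49 log units; beyond the scatter) and so points to weaker inhibition. This shows that the position is sensitive to a single added carbon, a sensitivity that the three earlier compounds, read only as separate points, could not reveal. In a physicochemical assay for solubility, measured as kinetic solubility, at pH 2 (on this read-out higher numbers stand for higher solubility and lower numbers for lower solubility), compound 3 gives 39100 nM and compound 4 gives 33900 nM; the same change reads as a 1.2-fold lower number from compound 3 to compound 4 (0.06 log units; within the scatter) and stays within the scatter, so the shift in inhibition has no counterpart on that read-out; nothing available bears on why the methyl has this effect.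

With only hydrogen and methyl shown on this carbon, it remains open whether an ethyl, a hydroxymethyl or an amine there would shift inhibition further in the same direction or reverse it. From the compounds shown here alone, it is also open whether the 5-methyl-4H-1,2,4-triazol-3-yl group would have a comparable effect on the core of compound 1, which carries the same unsubstituted ring.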